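Propoxy versus methoxy esters on a furanyl dihydropyrimidinone core

The source may report more compounds than this note shows. Statements on the series, on what has been measured and on what is new or still open speak of the compounds shown alone.

Measured compounds:
compound 1, `COC(=O)C1=C(C)NC(=O)NC1c1ccoc1`, 8%
compound 2, `CCCOC(=O)C1=C(C)NC(=O)NC1c1ccoc1`, 50%
compound 3, `COC(=O)C1=C(C)N(C)C(=O)NC1c1ccco1`, 45%

All three were tested in an assay on membranes from CHO cells for displacement of a labelled ligand from adenosine receptor A1 (Homo sapiens), read by scintillation counting, with a stated time of 60 min, tested at 1 uM; on this read-out lower numbers stand for less inhibition and higher numbers for more inhibition at the one concentration tested (going by the name of the read-out). Compound 1 gives 8% and sits at the bottom of the set. Compound 2 carries ethyl in place of hydrogen on a saturated chain carbon bound to an oxygen next to a carbonyl group relative to compound 1, and the step of a number 42 percentage points higher from compound 1 to compound 2 (beyond the scatter) is the one large movement in the set. Compound 3 gives 45%, which is within the scatter of compound 2 and well clear of compound 1; its core differs from the core of compound 1 in more than one place, and the difference between the two cores is not broken down here.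

Compound 4, `CCCOC(=O)C1=C(C)N(C)C(=O)NC1c1ccco1`, is not yet measured. Compared with compound 3 it shows (ethyl in place of hydrogen on a saturated chain carbon bound to an oxygen next to a carbonyl group), the same change as from compound 1 to compound 2, at a place that reads the same word for word. Going by the values given here, only one earlier instance of this change exists in the set, so the expectation rests on a single step.

On the core of compound 3 the expected step is a number 27 percentage points higher from compound 3 to compound 4 (beyond the scatter), taken as smaller than a number 42 percentage points higher from compound 1 to compound 2 (beyond the scatter) because compound 3 already starts from 45%, a much higher starting point than that of compound 1. For compound 4 the estimated value is 72%, with a range from 50% to 92%.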

Compound 4, a percentage reported as inhibition, at one concentration (the size of the read-out at that concentration, not a potency): 3%
Beside the measured number, compound 4's estimate is 69 percentage points above it; the measured number lies below the stated range.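

In this assay the change from methoxy to propoxy reverses direction on the core of compound 3, with a number 42 percentage points lower from compound 3 to compound 4 (beyond the scatter), so the two known instances of this change disagree in sign: the same change on two cores in this assay, a number 42 percentage points higher (beyond the scatter) from compound 1 to compound 2 and a number 42 percentage points lower (beyond the scatter) from compound 3 to compound 4, 84 percentage points apart, beyond the scatter of two such steps.

In this series, then, the outcome of this change depends on the core that carries it, and a step read on one core gives no safe forecast for another, even where the ester looks identical word for word. This does not show which feature of the core decides the direction: the core of compound 1 and the core of compound 3 differ in more than one place, the four compounds do not separate those places, and with only two instances no general rule for either core can be drawn.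

Still open, on these data alone, is how the read-out moves across the chain series on each core, for example with the ethoxy ester as an intermediate or with a longer chain such as butoxy. Also open, as far as these compounds go, is whether replacing the ester with a carboxylic acid or an amide on these two cores would give steps that run in the same direction.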